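Extending the amino acid side chain on a purine glycinamide

The source may report more compounds than this note shows. Statements on the series, on what has been measured and on what is new or still open speak of the compounds shown alone.

Compounds measured in a functional assay on the whole organism (Tail, strain ICR) with Mus musculus as the target, in the tail flick test, with a stated time of 60 min, at a dose of 25 umol/kg by the oral route (on this read-out higher numbers stand for a stronger effect at the one dose given and lower numbers for a weaker effect), so far:
- compound 1, `NC(=O)C[C@H](NC(=O)CN(c1nc(Cl)nc2[nH]cnc12)C1CC1)C(=O)O`, gives 43.1%.
- compound 2, `O=C(O)CNC(=O)CN(c1nc(Cl)nc2[nH]cnc12)C1CC1`, gives 38.9%.

Compound 2 stands lowest of the two measured numbers, but its nearest neighbour is compound 1, and the step of a number 4.2 percentage points lower from compound 1 to compound 2 (within the scatter) lies within the scatter, so the two compounds cannot be told apart on this read-out.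

Compound 3, `O=C(O)CC[C@H](NC(=O)CN(c1nc(Cl)nc2[nH]cnc12)C1CC1)C(=O)O`, has not yet been measured. It differs from compound 2 by 2-carboxyethyl in place of hydrogen on a saturated chain carbon bound to an amide-type nitrogen and a carbonyl carbon.

Among the measured compounds shown here, the only measured step that bears on this change is the one from compound 1 to compound 2, where a carbamoylmethyl group was removed from the same saturated chain carbon and the number moved by a number 4.2 percentage points lower from compound 1 to compound 2 (within the scatter), within the scatter. Compound 3 puts a 2-carboxyethyl group onto that same carbon. By analogy, compound 3 is expected to sit close to compound 2, with a step of a number 2.1 percentage points higher from compound 2 to compound 3 (within the scatter) that is not expected to exceed the scatter. Compound 3 is therefore estimated at 41%, with a range from 26% to 56%.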

Compound 3, a percentage reported as activity, at one dose (the size of the read-out at that dose, not a potency): 33.3%
For compound 3 the middle estimate is 7.7 percentage points above the measured one, and the stated range covers the measured number.
By their numbers in this assay, from the lowest: compounds 3, 2 and 1 (each within the scatter of the next).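

In this assay, 2-carboxyethyl in place of hydrogen on the saturated chain carbon bound to an amide-type nitrogen and a carbonyl carbon gives a number 5.6 percentage points lower from compound 2 to compound 3 (within the scatter). Among the compounds shown here, this position had so far been read only with carbamoylmethyl and hydrogen, and it now also carries a chain ending in a carboxylic acid without a step beyond the scatter. Carboxymethyl in place of carbamoyl on a saturated chain carbon, two bonds along the chain from an amide-type nitrogen and a carbonyl carbon, gives a number 9.8 percentage points lower from compound 1 to compound 3 (within the scatter), so the side chains of all three compounds remain indistinguishable on this read-out, and no measurement shown here offers an explanation for these numbers.

On these data alone, whether a group of another kind at this position, such as an aminobutyl chain or a benzyl group, would give a step beyond the scatter remains open. Also open, as far as these compounds go, is what a methyl ester in place of the carboxylic acid shared by these compounds would do, and since each number comes from a single dose, none of them speaks to potency.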